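The source may hold more compounds than are shown below. What is called first, only, known or untested is meant among the compounds shown, and "the series" means these compounds.

Working notes on the series, read in a functional assay on HeLa cells (Homo sapiens) for inhibition, read by trypan blue exclusion, with a stated time of 72 h; a lower number here means a stronger inhibitor of growth, a higher number a weaker inhibitor of growth. Compound 1 `CC/C(=C(\c1ccccc1)c1ccc(NC(=O)C(C)C)cc1)c1ccccc1` returns only a limit, > 30000 nM. Compound 2 `CC/C(=C(\c1ccccc1)c1ccc(NC(=O)C(C)C)cc1)c1ccc(OCc2ccccc2)cc1` gives 10200 nM, and compound 3 `CC/C(=C(/c1ccc(NC(=O)C(C)C)cc1)c1ccc(OC)cc1)c1ccc(OCc2ccccc2)cc1` gives 4200 nM. Compound 2 therefore holds the higher of the two numerical values, with compound 3 as its nearest neighbour.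

Two measured steps lead through compound 2. Adding a benzyloxy group gives an at least 2.9-fold lower number from compound 1 to compound 2 (0.46 log units; beyond the scatter). Adding a methoxy group gives a 2.4-fold lower number from compound 2 to compound 3 (0.39 log units; beyond the scatter). Both lie beyond the scatter and are modest in size.

The next comparison is compound 4 `CC/C(=C(/c1ccccc1)c1ccc(NC(=O)C(C)C)cc1)c1ccc(OCc2ccccc2)cc1`, with the two compounds have the same atoms and bonds and differ only in configuration as drawn: 1 of 1 stereo elements differ; a double bond is drawn Z in compound 2 and E in compound 4: a double bond is drawn Z in compound 2 and E in compound 4. The two compounds have the same atoms and bonds. Neither measured step changes configuration, so neither bears directly on this change and neither gives a direction. For the measured compounds named here, the one fully numerical step, a 2.4-fold lower number from compound 2 to compound 3 (0.39 log units; beyond the scatter), serves only as a rough scale for the range.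

The estimated step is a 1.1-fold lower number from compound 2 to compound 4 (0.05 log units; within the scatter), so no shift beyond the scatter is expected in this assay. For compound 4 the expected value is 9000 nM, with an estimated range of 3500 nM to 25000 nM.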

Compound 4, concentration for 50% growth inhibition: > 30000 nM
Compound 4 was reported as a limit; the forecaster's own chance of this, stated with the estimate: 10%; middle value at least 3.3-fold (0.52 log units) away from the limit.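

For the compounds shown here, the double-bond configuration matters in this assay, which the earlier steps could not show because each of them changed a substituent on an aromatic carbon and left the configuration as drawn untouched. Here no atom enters or leaves, yet the change from Z to E comes with an at least 2.9-fold higher number from compound 2 to compound 4 (0.46 log units; beyond the scatter), so the loss of growth inhibition can be assigned to the configuration alone, because of this: the fact that compounds 2 and 4 differ only in the configuration as drawn Compound 4 gives > 30000 nM, which is a limit and not a number, so the step is a lower bound and its full size stays unknown.

The compounds shown leave open whether the same dependence on configuration holds when the methoxy group of compound 3 is present, or when the benzyloxy group is replaced by another ether, such as a dimethylaminoethoxy chain. Also open, from the compounds shown here alone, is whether a hydroxyl group or a carboxylic acid on that aromatic ring would keep the difference between the Z and E forms, and whether changing the amide would alter it.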